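The source may report more compounds than this note shows. Statements on the series, on what has been measured and on what is new or still open speak of the compounds shown alone.

Measured compounds and their results:
Compound 1 `CN(C)c1c(C#N)c2c(N)ncnc2n1C` gives 3760 nM in an assay on isolated protein for inhibition of Leucine-rich repeat serine/threonine-protein kinase 2 variant G2019S (Homo sapiens), read by TR-FRET and LanthaScreen, with stated times of 50 min and 30 min, in the presence of a further agent that is not named here; a higher number here means a weaker inhibitor, a lower number a stronger inhibitor.
Compound 2 `Cc1c(Nc2nc(N)c3c(C#N)c(N4CCC[C@H]4C)n(C)c3n2)cnn1CC1(O)COC1` gives 10 nM in this assay.
Compound 3 `Cc1c(Nc2nc(N)c3c(C#N)c(N4CCC[C@H]4C)n(C)c3n2)cnn1C1COC1` gives 37 nM in this assay.

Among the three measured compounds, compound 1 has the highest number in this assay; its nearest neighbour is compound 3, and compound 2 lies further away still. For the measured compounds named here, the only measured step between compounds that differ in one place is a 3.7-fold higher number from compound 2 to compound 3 (0.57 log units; beyond the scatter), and that step concerns the group on the pyrazole nitrogen of the larger compounds, a part of the molecule that compound 1 does not carry.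

Compound 4 `Cn1c(N)c(C#N)c2c(N)ncnc21` differs from compound 1 by amino in place of dimethylamino on an aromatic carbon. No measured pair in this set changes the group at this carbon while keeping everything else the same, so no step shown here bears directly on the change from compound 1 to compound 4. Compounds 2 and 3 carry a different group at the same carbon, but they also carry the anilino substituent that compound 1 lacks, so their numbers cannot be assigned to either change alone. The expectation is therefore for compound 4 to remain close to compound 1, with a step of a 1.3-fold lower number from compound 1 to compound 4 (0.10 log units; within the scatter) that is not expected to exceed the scatter, and an estimated value for compound 4 of 3000 nM, within the range 800 nM to 12000 nM.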

Compound 4, half-maximal inhibitory concentration: 8560 nM
For compound 4 the middle estimate is 2.9-fold (0.46 log units) below the measured one, within the range that was stated.
By their numbers in this assay, from the lowest: compound 2; then compound 3; then compound 1; then compound 4.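

In this assay, for the compounds shown here, the pair of compound 1 and compound 4 gives the first measured change at this aromatic carbon, and the step is a 2.3-fold higher number from compound 1 to compound 4 (0.36 log units; beyond the scatter) when amino takes the place of dimethylamino. The number therefore responds to the group at this carbon even on the small shared core, although this single pair is modest in size and sets no trend. Nothing shown here explains the shift, and the loss of the methyl groups cannot be separated from the gain of the hydrogen-bond donor on the amino group.

As far as these compounds go, it remains open whether a methylamino group, which keeps only one methyl on the nitrogen, would give a number nearer to that of compound 1 or of compound 4, and whether a longer chain such as diethylamino or a ring amine such as morpholine would move the number the other way. From the compounds shown here alone, it is also open whether the same swap would give a step of similar size on the larger compounds, compound 2 and compound 3, which carry a further substituent on the shared core.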